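From cyano to (morpholin-4-yl)carbonyl on the shared core

The source may report more compounds than this note shows. Statements on the series, on what has been measured and on what is new or still open speak of the compounds shown alone.

Compound 1 `CCN1CCc2c(sc(NC(=O)Nc3cccc(Cl)c3Cl)c2C(N)=O)C1`: 17400 nM
Compound 2 `CCN1CCc2c(sc(NC(=O)Nc3ccc(Cl)cc3)c2C#N)C1`: > 25000 nM

In a functional assay (strain AB) with Danio rerio as the target, read by microscopy, with a stated time of 1 h (a higher number here means that more compound is needed for the effect, a lower number that less compound is needed), compound 2 gives no number, only a limit (> 25000 nM). Compound 3 `CCN1CCc2c(sc(NC(=O)Nc3ccc(Cl)cc3)c2C(=O)N2CCOCC2)C1` carries (morpholin-4-yl)carbonyl in place of cyano on an aromatic carbon. For the measured compounds named here, no measured step covers this change. Going by the values given here, the expectation rests on compound 1 (17400 nM), the only number available. The expected at least 1.1-fold lower number from compound 2 to compound 3 (0.05 log units; that floor lies within the scatter) in this assay is none beyond the scatter, with no direction favoured. Compound 3 is estimated at 22000 nM, with an expected range from 9000 nM to 50000 nM.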

Compound 3, half-maximal effective concentration: > 25000 nM
Compound 3 ended at the assay's limit; the forecaster's own chance of this, stated with the estimate: 55%; at least 1.1-fold (0.05 log units) between middle value and limit.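

For the compounds shown here, compound 2 and compound 3 both give only a limit in this assay, so no step between them can be read: the limit of > 25000 nM in this assay, at which 2 of the 3 values shown sit. As far as these compounds go, whether (morpholin-4-yl)carbonyl in place of cyano changes the required concentration at all remains open.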